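Cytotoxicity in Mouse Macrophage Cells: Two Limits, One Newcomer

This account rests on a few compounds, and the source may have more. Where it says the series, first, only, none or still open, it means among the compounds named here.

The compounds measured so far:

compound 1, `O=C1OC(Cc2nc(-c3ccc(-c4ccccc4)cc3)no2)c2ccccc21`: in an ADME assay on RAW264.7 cells (Mus musculus) for cytotoxicity, read by MTT assay, with a stated time of 24 h, in the absence of a further agent (a higher number here means a weaker inhibitor, a lower number a stronger inhibitor), compound 1 gives > 40000 nM, a limit of the assay rather than a number.
compound 2, `COCCCOc1ccc(C(O)C2OC(=O)c3c(OC)cc(OC)cc32)cc1`: in this assay compound 2 gives > 40000 nM, again a limit and not a number.

Neither compound, then, has a measured number in this assay; both stand at the same assay limit, (the limit of > 40000 nM in this assay, at which 2 of the 2 values shown sit). Compound 2 therefore stands exactly where compound 1 stands, at the limit, and nothing among the shown values places it higher or lower. Among the measured compounds shown here, no step between two measured compounds is available, so no measured shift can be read off.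

Compound 3, `COc1cc(OC)c2c(c1)C(C(O)c1ccc(OCc3ccc(OC(F)F)cc3)cc1)OC2=O`, is the compound still to be measured. It differs from compound 2 in one place: 4-(difluoromethoxy)phenyl in place of 2-methoxyethyl on a saturated chain carbon bound to an oxygen on an aromatic ring. With compound 2 sitting at the limit in this assay, the expectation is a step no larger than the scatter, a step that the limit leaves unreadable from compound 2 to compound 3, and most likely another limit. Compound 3 is thus estimated at 50000 nM, with a range from 20000 nM to 200000 nM.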

Compound 3, half-maximal inhibitory concentration: > 40000 nM
Compound 3 gave a limit, no number (the forecaster's own chance of this, stated with the estimate: 80%); the middle value lies beyond the limit too.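

Compound 2 and compound 3 each give only a limit, not a number, in this assay, so no step can be read between them. The compounds shown leave open at what concentration, if any, each would become toxic to these cells, and whether replacing 2-methoxyethyl with 4-(difluoromethoxy)phenyl changes that concentration.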